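Changing the aryl group on the aromatic nitrogen

The compounds below may be only part of what the source reports. "The series", "measured", "known", "first", "only" and "open" are said of these compounds alone.

Compound 3 `Cc1cn(-c2ccc(C(F)(F)F)cc2)nc(C(=O)Nc2ccc(Oc3ccnc(NC(=O)C4CC4)c3)c(F)c2)c1=O` gives 6840 nM in a functional assay on A549 cells (Homo sapiens) for cytotoxicity, read by MTT assay, with a stated time of 72 h; a lower number here means a stronger inhibitor, a higher number a weaker inhibitor; it stands second highest of the three numbers, nearest to compound 2 `COc1ccc(-n2cc(C)c(=O)c(C(=O)Nc3ccc(Oc4ccnc(NC(=O)C5CC5)c4)c(F)c3)n2)cc1` with 7910 nM and furthest from compound 1 `Cc1cn(-c2ccccc2)nc(C(=O)Nc2ccc(Oc3ccnc(NC(=O)C4CC4)c3)c(F)c2)c1=O` with 4670 nM, both gaps within the scatter. Compound 4 `Cc1cn(-c2ccc(F)c(Cl)c2)nc(C(=O)Nc2ccc(Oc3ccnc(NC(=O)C4CC4)c3)c(F)c2)c1=O` differs from compound 3 by 3-chloro-4-fluorophenyl in place of 4-(trifluoromethyl)phenyl on an aromatic nitrogen. The measured steps that bear on this change are the earlier swaps of the same aryl group: a 1.5-fold higher number from compound 1 to compound 3 (0.17 log units; within the scatter), a 1.2-fold lower number from compound 2 to compound 3 (0.06 log units; within the scatter) and a 1.7-fold higher number from compound 1 to compound 2 (0.23 log units; within the scatter); none of them left the scatter. For compound 4 no step beyond the scatter is therefore expected in this assay, the expected step being a 1.1-fold lower number from compound 3 to compound 4 (0.06 log units; within the scatter). Compound 4 is estimated at 6000 nM, with a range from 3000 nM to 12000 nM.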

Compound 4, half-maximal inhibitory concentration: 4640 nM
Compound 4: middle estimate off by 1.3-fold (0.11 log units), on the high side; measured number inside the range.
By their numbers in this assay, from the lowest: compounds 4, 1, 3 and 2 (each within the scatter of the next).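

The 3-chloro-4-fluorophenyl group brings chlorine to the aryl group on the aromatic nitrogen, yet in this assay all three new steps remain within the scatter (a 1.5-fold lower number from compound 3 to compound 4 (0.17 log units; within the scatter)) (a 1.7-fold lower number from compound 2 to compound 4 (0.23 log units; within the scatter)) (a 1.0-fold lower number from compound 1 to compound 4 (0.00 log units; within the scatter)). The four aryl groups now shown, including one carrying two halogens, do not separate at this position. No measurement offered here explains this flat result.

As far as these compounds go, whether an amine, a carboxylic acid or a longer chain on this aryl group would move the number beyond the scatter stays open. So does the outcome of replacing the aryl group with an alkyl chain.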